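Swapping a cyanophenyl for a methylpyridyl on a shared core

The source may hold more compounds than are shown below. What is called first, only, known or untested is meant among the compounds shown, and "the series" means these compounds.

Measured compounds:
`Cc1ccccc1-c1cc(F)cc(-n2nnc(-c3ccccn3)n2)c1` compound 1, 23 nM
`N#Cc1ccccc1-c1cc(F)cc(-n2nnc(-c3ccccn3)n2)c1` compound 2, 4 nM

Among the compounds with values here, in an assay for binding affinity to metabotropic glutamate receptor 5 (Rattus norvegicus) (on this read-out higher numbers stand for weaker inhibition and lower numbers for stronger inhibition), compound 2 has the lower of the two numbers, with compound 1 the only neighbour. Compound 3 is `Cc1ncccc1-c1cc(F)cc(-n2nnc(-c3ccccn3)n2)c1`; the change is 2-methylpyridin-3-yl in place of 2-cyanophenyl on an aromatic carbon. Within the data shown here, the one measured step that bears on it, a 5.8-fold lower number from compound 1 to compound 2 (0.76 log units; beyond the scatter), shows that trading a methyl for a cyano at this spot moved the number by a modest amount. Since compound 3 carries a methyl again, a step back in the opposite direction is expected, a 3.8-fold higher number from compound 2 to compound 3 (0.57 log units; beyond the scatter). For compound 3 the estimate is 15 nM, within 5 nM to 45 nM.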

Compound 3, inhibition constant: 45 nM
Beside the measured number, compound 3's estimate is 3.0-fold (0.48 log units) below it; measured number inside the range.
By their numbers in this assay, from the lowest: compound 2; then compounds 1 and 3 (each within the scatter of the next).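

In this assay the step of an 11-fold higher number from compound 2 to compound 3 (1.05 log units; beyond the scatter) shows that 2-methylpyridin-3-yl does not keep the low number that 2-cyanophenyl gave on this aromatic carbon. The step of a 2.0-fold higher number from compound 1 to compound 3 (0.29 log units; within the scatter) shows that, with the methyl kept, changing a ring carbon to nitrogen leaves the number within the scatter, so here the nitrile-bearing ring stands apart from both methyl-bearing rings. No available evidence explains this difference. Still open, going by these compounds, is how 2-cyanopyridin-3-yl, which combines the nitrile with the ring nitrogen, would behave, and how a methoxy group or an amine would compare in place of the methyl.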